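Pyrimidine substituent swap on a series stuck at the limit

The compounds below may be only part of what the source reports. "The series", "measured", "known", "first", "only" and "open" are said of these compounds alone.

Compound 1 `CC(C)[C@H](NC(=O)COc1cccc2ccccc12)C(=O)N[C@@H](CC(=O)O)C(=O)CSc1ncc[nH]1`, compound 2 `CC(C)[C@H](NC(=O)COc1cccc2ccccc12)C(=O)N[C@@H](CC(=O)O)C(=O)CSC1=NCCS1` and compound 3 `Cc1cc(OCC(=O)[C@H](CC(=O)O)NC(=O)[C@@H](NC(=O)COc2cccc3ccccc23)C(C)C)nc(C)n1` share one core and differ only in the group on a saturated chain carbon bound to a carbonyl carbon. In a functional assay on Jurkat cells (Homo sapiens) for inhibition (on this read-out higher numbers stand for weaker inhibition and lower numbers for stronger inhibition), compound 1 gives the limit > 200000 nM. Compound 2 gives the limit > 200000 nM in this assay. Compound 3 also gives the limit > 200000 nM in this assay. Hence the steps a step that the two limits leave unreadable from compound 1 to compound 2, a step that the two limits leave unreadable from compound 1 to compound 3 and a step that the two limits leave unreadable from compound 2 to compound 3 cannot be read, as the limit of > 200000 nM in this assay, at which 3 of the 3 values shown sit, shows. Compound 4 `CC(C)[C@H](NC(=O)COc1cccc2ccccc12)C(=O)N[C@@H](CC(=O)O)C(=O)COc1ccnc(C(F)(F)F)n1` carries 2-(trifluoromethyl)pyrimidin-4-yl in place of 2,6-dimethylpyrimidin-4-yl on an oxygen on a saturated carbon. Going by the values given here, none of the measured steps gives a readable size for such a change. The step of a number no higher from compound 3 to compound 4 (the limit leaves the size open) is expected to be nothing beyond the scatter. Compound 4 is therefore expected to sit again at the limit, estimated at 200000 nM, between 50000 nM and 200000 nM.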

Compound 4, half-maximal inhibitory concentration: 37000 nM
The estimate for compound 4 lay 5.4-fold (0.73 log units) above the measured number, outside the stated range (below it).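

In this assay, going by these compounds alone, the step of an at least 5.4-fold lower number from compound 3 to compound 4 (0.73 log units; beyond the scatter) is the first readable change, made by 2-(trifluoromethyl)pyrimidin-4-yl in place of 2,6-dimethylpyrimidin-4-yl on the oxygen. The steps of an at least 5.4-fold lower number from compound 2 to compound 4 (0.73 log units; beyond the scatter) and an at least 5.4-fold lower number from compound 1 to compound 4 (0.73 log units; beyond the scatter) are likewise readable, whereas those among compound 1, compound 2 and compound 3 cannot be read. Only compound 4 has a number off the limit: the limit of > 200000 nM in this assay, at which 3 of the 4 values shown sit.

From the compounds shown here alone, compound 3 stands only at a limit, so the full size of the step stays open. Also open, going by these compounds, is whether a nitrile or a chlorine in place of the trifluoromethyl would lower the number too.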